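The source may report more compounds than this note shows. Statements on the series, on what has been measured and on what is new or still open speak of the compounds shown alone.

Measured in a functional assay on L1210 cells (Mus musculus) for antiproliferative activity; a lower number here means a stronger inhibitor, a higher number a weaker inhibitor:
- Compound 1 `COc1cc(C(=O)c2sc(-c3ccccc3)cc2N)cc(OC)c1OC`: 11 nM
- Compound 2 `COc1cc(C(=O)c2sc(-c3ccc(F)cc3)cc2N)cc(OC)c1OC`: 20 nM
- Compound 3 `CCOc1ccc(-c2cc(N)c(C(=O)c3cc(OC)c(OC)c(OC)c3)s2)cc1`: 590 nM

Compound 3 is the weakest of the three, as both a 54-fold higher number from compound 1 to compound 3 (1.73 log units; beyond the scatter) and a 30-fold higher number from compound 2 to compound 3 (1.47 log units; beyond the scatter) show. Compound 4 `COc1cc(C(=O)c2sc(-c3ccc(C(F)(F)F)cc3)cc2N)cc(OC)c1OC` has not yet been measured. It carries trifluoromethyl in place of ethoxy on an aromatic carbon.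

Two measured steps at this carbon bear on the change. Fluoro in place of hydrogen gave a 1.8-fold higher number from compound 1 to compound 2 (0.26 log units; within the scatter), which stays within the scatter, whereas ethoxy in place of hydrogen gave the large 54-fold higher number from compound 1 to compound 3 (1.73 log units; beyond the scatter). Trifluoromethyl contains fluorine, as compound 2 does, but like ethoxy it is a group rather than a lone atom. For the measured compounds named here, no measured compound carries it, so these results only loosely bracket the outcome. A partial return towards compound 1 and compound 2 is expected, with an estimated 4.9-fold lower number from compound 3 to compound 4 (0.69 log units; beyond the scatter). For compound 4, the estimated value is 120 nM, with an expected range of 25 nM to 600 nM.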

Compound 4, half-maximal inhibitory concentration: 370 nM
Beside the measured number, compound 4's estimate is 3.1-fold (0.49 log units) below it; measured number inside the range.
By their numbers in this assay, from the lowest: compounds 1 and 2 (each within the scatter of the next); then compounds 4 and 3 (each within the scatter of the next).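

In this assay, trifluoromethyl and ethoxy at this carbon cannot be told apart (a 1.6-fold lower number from compound 3 to compound 4 (0.20 log units; within the scatter)). Trifluoromethyl instead separates clearly from both smaller substituents (a 19-fold higher number from compound 2 to compound 4 (1.27 log units; beyond the scatter); a 34-fold higher number from compound 1 to compound 4 (1.53 log units; beyond the scatter)), so the tolerance seen for fluoro does not extend to this fluorine-containing group, and the large rise in the number is not unique to ethoxy. Among these four compounds, hydrogen and fluoro form one group and ethoxy and trifluoromethyl another, but nothing available here explains that split.

The compounds shown leave open where a methyl group, a chlorine atom or an amine at this carbon would fall relative to those two groups. They also leave open whether a longer chain than ethoxy would give a number close to those of compound 3 and compound 4.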